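Replacing Fluoro with Benzylcarbamoyl on the Shared Core

The compounds below may be only part of what the source reports. "The series", "measured", "known", "first", "only" and "open" are said of these compounds alone.

Of the compounds shown here, two have so far been measured for an assay on isolated protein for inhibition of Rho-associated protein kinase 2 (Homo sapiens); a lower number here means a stronger inhibitor, a higher number a weaker inhibitor. Compound 1 `Cc1[nH]ncc1-c1ccc2nc(C3COc4ccccc4C3)oc2c1` gives 9 nM. Compound 2 `Nc1nccc(-c2ccc3nc(C4COc5ccc(F)cc5C4)[nH]c3c2)n1` gives 6 nM, the lower of the two numbers, though its gap to compound 1 lies within the usual scatter, so the two cannot be set in order. Compound 3 `Nc1nccc(-c2ccc3nc(C4COc5ccc(C(=O)NCc6ccccc6)cc5C4)[nH]c3c2)n1` has not yet been measured. It differs from compound 2 in one place: benzylcarbamoyl in place of fluoro on an aromatic carbon. Among the compounds with values here, no measured pair shows what a change of this kind does here, so the expectation rests on compound 2 alone, whose value of 6 nM is the starting point. With a much larger group entering, the outcome is uncertain; a small loss seems somewhat more likely than a gain, and a step within the scatter is also possible. The step from compound 2 to compound 3 is estimated as a 2.5-fold higher number from compound 2 to compound 3 (0.40 log units; beyond the scatter). Compound 3 is expected to give about 15 nM, within a range from 3 nM to 80 nM.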

Compound 3, half-maximal inhibitory concentration: < 1 nM
Compound 3 was reported as a limit; the forecaster's own chance of this, stated with the estimate: 2%; middle value at least 15-fold (1.17 log units) from the limit.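

In this assay compound 3 gives < 1 nM, which is a limit of the assay and not an exact number. Benzylcarbamoyl in place of fluoro on this aromatic carbon gives an at least 6.0-fold lower number from compound 2 to compound 3 (0.77 log units; beyond the scatter), so this position accepts a much larger group that brings its own aromatic ring, and the inhibition gets stronger rather than weaker. How far the step really extends cannot be told, because of what the assay can report: the limit of < 1 nM in this assay, at which 1 of the 3 values shown sits.

The compounds shown do not separate the contribution of the carbonyl and amide hydrogen from that of the benzyl ring, and a plain carboxamide, a carboxylic acid or a simple amine at this position could help to tell them apart. On these data alone, whether the same change would have a similar effect on the core of compound 1 also remains open.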